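This account rests on a few compounds, and the source may have more. Where it says the series, first, only, none or still open, it means among the compounds named here.

Measured so far in a functional assay on the whole organism (artery, strain albino) with Rattus norvegicus as the target, with a stated time of 600 min, at a dose of 10 mg/kg by the oral route; on this read-out higher numbers stand for more inhibition at the one dose given (going by the name of the read-out) and lower numbers for less inhibition:

- compound 1 `COc1ccc(C2N=C(SCc3cccc(Cl)c3)NC(C)=C2C(=O)Nc2ccc(F)cc2)cc1OC` gives 17.4%
- compound 2 `COc1ccc(C2N=C(SCc3ccc(Cl)cc3)NC(C)=C2C(=O)Nc2ccc(F)cc2)cc1OC` gives 26.7%
- compound 3 `CC1=C(C(=O)Nc2ccc(F)cc2)C(c2ccc([N+](=O)[O-])cc2)N=C(SCc2cccc(Cl)c2)N1` gives 16.4%

Three compounds share a core; compound 3 differs from compound 1 by 4-nitrophenyl in place of 3,4-dimethoxyphenyl on a saturated ring carbon, and in this assay that gives a number 1 percentage points lower from compound 1 to compound 3 (within the scatter). Compound 4 `CC1=C(C(=O)Nc2ccc(F)cc2)C(c2ccc([N+](=O)[O-])cc2)N=C(SCc2ccc(Cl)cc2)N1` is not yet measured. It differs from compound 3 by 4-chlorophenyl in place of 3-chlorophenyl on a saturated chain carbon bound to a sulfur. The same change is already seen once, from compound 1 to compound 2, as 4-chlorophenyl in place of 3-chlorophenyl on a saturated chain carbon bound to a sulfur, where the place is the same word for word, and in this assay it gives a number 9.3 percentage points higher from compound 1 to compound 2 (within the scatter). Two instances in all; the earlier one stays within the scatter, so little weight can rest on it. Among the compounds with values here, for compound 4 in this assay a step of a number 5.6 percentage points higher from compound 3 to compound 4 (within the scatter) is expected, resting on the single earlier step of a number 9.3 percentage points higher from compound 1 to compound 2 (within the scatter) and on the starting point of compound 3, which gives 16.4%. The estimate for compound 4 in this assay is 22%, expected between 10% and 34%.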

Compound 4, a percentage reported as inhibition, in the whole organism at one dose (the size of the read-out at that dose, not a potency): 28.2%
Compound 4: the middle estimate sits 6.2 percentage points below what was measured; the range from low to high includes it.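

In this assay, 4-chlorophenyl in place of 3-chlorophenyl on a saturated chain carbon bound to a sulfur carries over to the core bearing 4-nitrophenyl, with a number 11.8 percentage points higher from compound 3 to compound 4 (beyond the scatter), and the two instances agree: the same change on two cores in this assay, a number 9.3 percentage points higher (within the scatter) from compound 1 to compound 2 and a number 11.8 percentage points higher (beyond the scatter) from compound 3 to compound 4, 2.5 percentage points apart, within the scatter of two such steps. On a saturated ring carbon, 4-nitrophenyl in place of 3,4-dimethoxyphenyl gives a number 1.5 percentage points higher from compound 2 to compound 4 (within the scatter), and this change also reads alike in both settings: the same change on two cores in this assay, a number 1 percentage points lower (within the scatter) from compound 1 to compound 3 and a number 1.5 percentage points higher (within the scatter) from compound 2 to compound 4, 2.5 percentage points apart, within the scatter of two such steps. This shows that the two changes combine consistently across these four compounds, at one dose, but it does not establish a rule for any other core.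

Still open, as far as these compounds go, is whether the step holds with a methoxy or trifluoromethyl group in place of the chlorine. From the compounds shown here alone, a longer chain in place of the benzyl on the sulfur also remains open.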